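The source may report more compounds than this note shows. Statements on the series, on what has been measured and on what is new or still open speak of the compounds shown alone.

Compound 2 `COc1ccc(S(=O)(=O)c2cc(N)c3ncccc3c2[N+](=O)[O-])cc1` is the weaker of the two measured compounds: in an assay for binding affinity to Neuropeptide Y receptor type 1 (Homo sapiens), read by radioligand binding (on this read-out lower numbers stand for stronger inhibition and higher numbers for weaker inhibition), compound 2 gives 1140 nM, while its nearest neighbour, compound 1 `Nc1cc(S(=O)(=O)c2ccccc2)c([N+](=O)[O-])c2cccnc12`, gives 297 nM in this assay. Within the data shown here, the one measured step, a 3.8-fold higher number from compound 1 to compound 2 (0.58 log units; beyond the scatter), is the only guide available for the change now considered. Compound 3 `Nc1cc(S(=O)(=O)c2ccc(Cl)cc2)c([N+](=O)[O-])c2cccnc12` differs from compound 2 by chloro in place of methoxy on an aromatic carbon. Among the measured compounds shown here, no measured pair shows chloro at that position, so the step is read only indirectly: the methoxy that enters in a 3.8-fold higher number from compound 1 to compound 2 (0.58 log units; beyond the scatter) leaves again here, and what the chloro adds is unknown. The expectation is therefore that compound 3 moves back toward compound 1, giving a lower number than compound 2 in this assay by about a 2.3-fold lower number from compound 2 to compound 3 (0.36 log units; beyond the scatter), with wide uncertainty. The estimate for compound 3 in this assay is 500 nM, within a range from 150 nM to 1700 nM.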

Compound 3, inhibition constant: 1750 nM
Compound 3: the middle estimate sits 3.5-fold (0.54 log units) below what was measured; measured number above the stated range.
By their numbers in this assay, from the lowest: compound 1; then compounds 2 and 3 (each within the scatter of the next).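

In this assay, the step from methoxy to chloro at this position is a 1.5-fold higher number from compound 2 to compound 3 (0.19 log units; within the scatter), so the two groups cannot be told apart on this read-out. Chloro in place of hydrogen gives a 5.9-fold higher number from compound 1 to compound 3 (0.77 log units; beyond the scatter), a step in the same direction as a 3.8-fold higher number from compound 1 to compound 2 (0.58 log units; beyond the scatter). Hydrogen therefore gives the lowest number of the three, and in these two cases the higher number goes with a group other than hydrogen, whichever of the two it is. Nothing available explains why these two groups read alike.

As far as these compounds go, it remains open whether fluoro, methyl or an amine at this place would also give a higher number than hydrogen. From the compounds shown here alone, it is equally open whether a carboxylic acid or a longer chain there would read like methoxy and chloro or differ from them.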